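Nitro for Trifluoromethyl on the Ester-Linked Stilbene Series

A few compounds are considered here, and "the series" means these few. Any claim that something is new, unique, unknown or untested is made for them only; others in the source may bear on it.

Compound 1 `COc1cc(/C=C/c2ccc(NC(=O)/C=C/c3ccc(C(F)(F)F)cc3)cc2)cc(OC)c1`: 3520 nM
Compound 2 `COc1cc(/C=C/c2ccc(NC(=O)/C=C/c3ccc([N+](=O)[O-])cc3)cc2)cc(OC)c1`: 11700 nM
Compound 3 `COc1cc(/C=C/c2ccc(OC(=O)/C=C/c3ccc(C(F)(F)F)cc3)cc2)cc(OC)c1`: 6910 nM

Of the compounds shown here, three have been measured in a functional assay on MDA-MB-231 cells (Homo sapiens) for inhibition, read by MTT assay, with a stated time of 48 h; on this read-out higher numbers stand for weaker inhibition and lower numbers for stronger inhibition. In this assay compound 1 gives 3520 nM, compound 2 gives 11700 nM, and compound 3 gives 6910 nM. Compound 2 differs from compound 1 by a single change, (nitro in place of trifluoromethyl on an aromatic carbon), and this change gave a 3.3-fold higher number from compound 1 to compound 2 (0.52 log units; beyond the scatter). Compound 3 carries a different core from compound 1; how the two cores differ is not broken down here. The values of compound 3 and compound 1 lie within the usual scatter of each other, as do those of compound 3 and compound 2, so no order among them can be stated.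

Compound 4 `COc1cc(/C=C/c2ccc(OC(=O)/C=C/c3ccc([N+](=O)[O-])cc3)cc2)cc(OC)c1` has not yet been measured. It differs from compound 3 by nitro in place of trifluoromethyl on an aromatic carbon. This is the same change that separates compound 2 from compound 1, at the same place on the ring. Going by the values given here, the step from compound 3 to compound 4 is expected to be a 2.9-fold higher number from compound 3 to compound 4 (0.46 log units; beyond the scatter), because the one earlier instance of this change gave a 3.3-fold higher number from compound 1 to compound 2 (0.52 log units; beyond the scatter), though a single instance on a different core leaves room for the step to fall short of or exceed that size. Compound 4 is therefore estimated at 20000 nM in this assay, with an expected range from 8000 nM to 50000 nM.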

Compound 4, half-maximal inhibitory concentration: 18000 nM
The estimate for compound 4 lay 1.1-fold (0.05 log units) above the measured number; measured number inside the range.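

In this assay, nitro in place of trifluoromethyl on the second core gave a 2.6-fold higher number from compound 3 to compound 4 (0.42 log units; beyond the scatter). The change therefore carried from one core to the other in this series, in the same direction and with no size difference that can be told apart: the same change on two cores in this assay, a 3.3-fold higher number (0.52 log units; beyond the scatter) from compound 1 to compound 2 and a 2.6-fold higher number (0.42 log units; beyond the scatter) from compound 3 to compound 4, 1.3-fold (0.11 log units) apart, within the scatter of two such steps. Going by these compounds alone, this rests on only two cores, one pair of groups and one assay, so it does not show that the step would hold on any further core, and it does not show what in the change drives the higher number.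

The compounds shown leave open whether other groups on the same aromatic carbon, such as an amine, a nitrile or a carboxylic acid, would follow the trend set by trifluoromethyl and nitro on both cores. They also leave open whether the step would keep its size if a longer chain replaced the link that carries the 4-(trifluoromethyl)phenyl or 4-nitrophenyl group, or if the change were tested on cells other than those used here.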